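Chloro in place of hydrogen: a forecast for compound 4

This account rests on a few compounds, and the source may have more. Where it says the series, first, only, none or still open, it means among the compounds named here.

Of the compounds shown here, three sharing one core have been measured in an assay on HEK293 cells for inhibition of transient receptor potential cation channel subfamily M member 8 (Homo sapiens), read by FLIPR, with stated times of 5 min and 3 min; a higher number here means a weaker inhibitor, a lower number a stronger inhibitor. Compound 1 `CCOC(=O)c1sc(-c2ccc(C)cc2)nc1O` gives 160 nM, compound 2 `CCOC(=O)c1sc(-c2ccc(F)cc2)nc1O` gives 80 nM, and compound 3 `CCOC(=O)c1sc(-c2ccccc2)nc1O` gives 32 nM. Compound 3 thus stands at the lowest number of the three: a 5.0-fold lower number from compound 1 to compound 3 (0.70 log units; beyond the scatter) and a 2.5-fold lower number from compound 2 to compound 3 (0.40 log units; beyond the scatter), both beyond the scatter, whereas a 2.0-fold lower number from compound 1 to compound 2 (0.30 log units; within the scatter) stays within it.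

Compound 4 `CCOC(=O)c1sc(-c2ccc(Cl)cc2)nc1O` is not yet measured. It differs from compound 3 by chloro in place of hydrogen on an aromatic carbon, the chloro entering on an aromatic carbon para to a large group. Within the data shown here, the steps that bear on this are the two in which a group at that same place was removed, a 5.0-fold lower number from compound 1 to compound 3 (0.70 log units; beyond the scatter) and a 2.5-fold lower number from compound 2 to compound 3 (0.40 log units; beyond the scatter), each a modest move toward lower numbers once the ring carbon was left bare. Placing chloro there is therefore expected to move the number upward by a modest amount in this assay, a 3.1-fold higher number from compound 3 to compound 4 (0.49 log units; beyond the scatter). Compound 4 is estimated at 100 nM, with a range from 40 nM to 250 nM.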

Compound 4, half-maximal inhibitory concentration: 550 nM
Compound 4: the middle estimate sits 5.5-fold (0.74 log units) below what was measured, outside the stated range (above it).
By their numbers in this assay, from the lowest: compound 3; then compounds 2 and 1 (each within the scatter of the next); then compound 4.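

Among these compounds, compound 4 shows that the aromatic carbon para to a large group does more than tolerate substituents to a modest degree: in this assay, chloro there gives a 17-fold higher number from compound 3 to compound 4 (1.24 log units; beyond the scatter), the only large step. Chloro also separates from the two groups already tried at that carbon, with a 6.9-fold higher number from compound 2 to compound 4 (0.84 log units; beyond the scatter) and a 3.4-fold higher number from compound 1 to compound 4 (0.54 log units; beyond the scatter), whereas fluoro and methyl lie within the scatter of each other. All three substituted compounds thus have higher numbers than the unsubstituted compound 3, but the size of the rise depends on which group enters, and nothing available explains why chloro stands apart. The compounds shown leave open how a bromo, methoxy or amino group would behave at this carbon, and whether chloro on another carbon of the same ring would raise the number as much.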